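Three Limits and One Changed Aryl Group

The compounds below may be only part of what the source reports. "The series", "measured", "known", "first", "only" and "open" are said of these compounds alone.

Measured in a functional assay on NALM-6 cells (Homo sapiens) for cytotoxicity, with a stated time of 72 h; a lower number here means that less compound is needed, a higher number that more compound is needed for the effect:

compound 1 `C=C[C@@](C)(/C=C/c1ccc(Nc2ccccc2)cc1)CCC=C(C)C` gives > 43400 nM (a limit)
compound 2 `C=C[C@@](C)(/C=C/c1ccc(Nc2cc(F)cc(F)c2)cc1)CCC=C(C)C` gives > 43400 nM (a limit)
compound 3 `C=C[C@@](C)(/C=C/c1ccc(Nc2ccc(Cl)c(F)c2)cc1)CCC=C(C)C` gives > 43400 nM (a limit)

In this assay compound 3 gives > 43400 nM, which is a limit and not a number. The same is true of the other two measured compounds, so the series offers the limit of > 43400 nM in this assay, at which 3 of the 3 values shown sit, and no graded value against which compound 3 can be placed.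

The next compound is compound 4 `C=C[C@@](C)(/C=C/c1ccc(-c2ccc(Cl)cc2)cc1)CCC=C(C)C`, and the structural change from compound 3 is 4-chlorophenyl in place of (4-chloro-3-fluorophenyl)amino on an aromatic carbon. In words, this is 4-chlorophenyl in place of (4-chloro-3-fluorophenyl)amino on an aromatic carbon, so the nitrogen is gone as well.

Three measured steps lie nearest to this change: a step that the two limits leave unreadable from compound 1 to compound 2, a step that the two limits leave unreadable from compound 1 to compound 3 and a step that the two limits leave unreadable from compound 2 to compound 3. Their sizes cannot be read, and each of them only exchanges the group on the nitrogen. None of them removes the nitrogen, so they bear on the new change only indirectly.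

Because the limit of > 43400 nM in this assay, at which 3 of the 3 values shown sit, describes compound 3 and both its relatives, compound 4 is also expected to sit near that limit. The expectation is a step that the limit leaves unreadable from compound 3 to compound 4, with no step beyond the scatter in either direction. The estimate for compound 4 is 45000 nM, with an expected range from 20000 nM to 90000 nM.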

Compound 4, half-maximal effective concentration: > 43400 nM
Compound 4: no number, only a limit; the forecaster's own chance of this, stated with the estimate: 80%; the middle value lies beyond the limit too.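

In this assay compound 4 gives > 43400 nM, which is a limit and not a number. The steps to compound 4 from compound 1, compound 2 and compound 3 therefore cannot be read, and the series still holds only: the limit of > 43400 nM in this assay, at which 4 of the 4 values shown sit. The compounds shown leave open whether any group on the shared core gives a graded value in this assay.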